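This account rests on a few compounds, and the source may have more. Where it says the series, first, only, none or still open, it means among the compounds named here.

Measured compounds:
compound 1 `CCCCCCNC(=O)/N=C(\N)NCCCc1sc(N)nc1C` — 28.8 nM
compound 2 `Cc1nc(N)sc1CCCN/C(N)=N/C(=O)NCc1ccccc1` — 69.2 nM
compound 3 `Cc1nc(N)sc1CCCN/C(N)=N/C(=O)NCc1ccco1` — 10.5 nM

In an assay on membranes from Sf9 cells for displacement of a labelled ligand from histamine H2 receptor (Homo sapiens), read by scintillation counting, with a stated time of 60 min (on this read-out higher numbers stand for weaker inhibition and lower numbers for stronger inhibition), compound 3 gives the lowest of the three numbers. Compound 1 lies nearest to it, as seen in a 2.7-fold lower number from compound 1 to compound 3 (0.44 log units; beyond the scatter), and compound 2 lies furthest, as seen in a 6.6-fold lower number from compound 2 to compound 3 (0.82 log units; beyond the scatter). Compound 2 and compound 1 are also separated, as seen in a 2.4-fold higher number from compound 1 to compound 2 (0.38 log units; beyond the scatter), so among these three, substitution on the saturated chain carbon bound to the amide-type nitrogen has mattered, with furan-2-yl giving the lowest number and phenyl the highest.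

Compound 4 `Cc1nc(N)sc1CCCN/C(N)=N/C(=O)Nc1ccccc1` is not yet measured. It differs from compound 3 by phenyl in place of (furan-2-yl)methyl on an amide-type nitrogen. Going by the values given here, none of the measured steps covers this change exactly: all three alter the group on the chain carbon and keep that carbon in place, while here the carbon itself is removed and phenyl sits directly on the nitrogen. The step that bears most closely is a 6.6-fold lower number from compound 2 to compound 3 (0.82 log units; beyond the scatter), where phenyl gave the higher number, and a 2.4-fold higher number from compound 1 to compound 2 (0.38 log units; beyond the scatter) points the same way for phenyl. Compound 4 is therefore expected to show a higher number in this assay than compound 3, with an estimated step of a 4.8-fold higher number from compound 3 to compound 4 (0.68 log units; beyond the scatter). Compound 4 is estimated at 50 nM, with a range from 15 nM to 170 nM.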

Compound 4, inhibition constant: 3160 nM
Estimate against measurement, compound 4: 63-fold (1.80 log units) below; measured number outside the range, above it.
By their numbers in this assay, from the lowest: compound 3; then compound 1; then compound 2; then compound 4.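

Set against the earlier compounds, compound 4 shows that in this assay the saturated carbon on the amide-type nitrogen counts for far more than the group it carries: changing that group had produced only modest steps, whereas phenyl in place of benzyl gives a large one (a 46-fold higher number from compound 2 to compound 4 (1.66 log units; beyond the scatter)). This is the closest comparison, as the ring stays a phenyl and only the carbon linking it to the nitrogen is gone. The wider gaps to the other two compounds (a 300-fold higher number from compound 3 to compound 4 (2.48 log units; beyond the scatter)) and (a 110-fold higher number from compound 1 to compound 4 (2.04 log units; beyond the scatter)) put compound 4 far from all three compounds with a saturated carbon at this place, whether that carbon carries furan-2-yl, phenyl or pentyl, and nothing available here accounts for the size of this gap.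

The compounds shown leave open whether the large step belongs to the lost carbon or to an aromatic ring standing on the amide-type nitrogen, a question that a cyclohexyl group on that nitrogen would address. They also leave open how the number moves with a longer link, as in a phenethyl group, and whether furan-2-yl on that nitrogen would follow phenyl.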